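Phenoxy for Methoxy: Cytotoxicity Expected to Remain Unseen

The compounds below may be only part of what the source reports. "The series", "measured", "known", "first", "only" and "open" are said of these compounds alone.

Of the compounds shown here, three built on one shared core have been tested in an ADME assay on Vero cells (Chlorocebus sabaeus) for cytotoxicity, read by sulforhodamine B assay, with a stated time of 72 h; on this read-out lower numbers stand for stronger inhibition and higher numbers for weaker inhibition. Compound 1 `CN1Cc2ccc(OCc3ccccc3)cc2[C@@H](O)C1` gives only a limit of the assay, > 100000 nM. Compound 2 `CN1Cc2ccc(OCc3ccc([N+](=O)[O-])cc3)cc2[C@@H](O)C1` likewise gives a limit, > 50000 nM. Compound 3 `COc1ccc(COc2ccc3c(c2)[C@@H](O)CN(C)C3)cc1` stands at a limit as well, > 50000 nM, so its place on the numbers is known only as a boundary, not as a point, and the same holds for the two other values. One value sits at the limit of > 100000 nM in this assay, at which 1 of the 3 values shown sits, and two at the limit of > 50000 nM in this assay, at which 2 of the 3 values shown sit, which leaves the steps a step that the two limits leave unreadable from compound 1 to compound 2, a step that the two limits leave unreadable from compound 1 to compound 3 and a step that the two limits leave unreadable from compound 2 to compound 3 without a readable size.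

Compound 4 `CN1Cc2ccc(OCc3ccc(Oc4ccccc4)cc3)cc2[C@@H](O)C1` differs from compound 3 by phenyl in place of methyl on an oxygen on an aromatic ring. Going by the values given here, no measured step bears on this change with a readable size, so the expectation rests on the limits alone. For compound 4 the step that the limit leaves unreadable from compound 3 to compound 4 is expected to stay within the scatter in this assay. Compound 4 is therefore estimated at 70000 nM, ranging from 20000 nM to 200000 nM, most likely again reported only as a limit.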

Compound 4, half-maximal inhibitory concentration: 3400 nM
Estimate against measurement, compound 4: 21-fold (1.31 log units) above; the whole stated range lies above it.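

Phenoxy is the first group at this place to bring a readable number in this assay, and the change from methoxy gives an at least 14-fold lower number from compound 3 to compound 4 (1.16 log units; beyond the scatter). The same comparison against the other two compounds gives an at least 14-fold lower number from compound 2 to compound 4 (1.16 log units; beyond the scatter) and an at least 29-fold lower number from compound 1 to compound 4 (1.46 log units; beyond the scatter), so cytotoxicity in this small set does respond to what sits at this place, which hydrogen, nitro and methoxy did not reveal. The steps among compound 1, compound 2 and compound 3 cannot be read, and the three new steps give only minimum sizes, because those compounds stand at limits of the assay, as here: the limit of > 50000 nM in this assay, at which 2 of the 4 values shown sit.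

As far as these compounds go, with only compound 4 giving a number, it remains open whether the phenyl ring itself matters or whether any larger group would do the same. A cyclohexyloxy group or a butoxy chain in place of phenoxy would help to separate these two readings.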